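The compounds below may be only part of what the source reports. "The series", "measured", "known", "first", "only" and "open" are said of these compounds alone.

Measured in a functional assay on MCF7 cells (Homo sapiens) for inhibition, read by MTT assay, with a stated time of 24 h; on this read-out lower numbers stand for stronger inhibition of growth and higher numbers for weaker inhibition of growth:

- compound 1 `COc1ccc2c(c1)c(-c1nc3ccccc3n1C(=O)c1ccccc1OC)cn2C`: 23900 nM
- compound 2 `COc1cccc(C(=O)n2c(-c3cn(C)c4ccc(OC)cc34)nc3ccccc32)c1`: 14600 nM
- compound 3 `COc1ccc2c(c1)c(-c1nc3ccccc3n1C(=O)c1ccc(OC)c(OC)c1)cn2C`: 6300 nM

Compound 1 lies at the weak end of this small set, alongside compound 2, as the step between them shows: a 1.6-fold lower number from compound 1 to compound 2 (0.21 log units; within the scatter). Compound 3 stands clearly apart from it: a 3.8-fold lower number from compound 1 to compound 3 (0.58 log units; beyond the scatter). The next compound, compound 4 `COc1ccccc1C(=O)n1c(-c2cn(C)c3ccc(Br)cc23)nc2ccccc21`, keeps the 2-methoxyphenyl on the carbonyl carbon and changes the core of compound 1 instead: bromo in place of methoxy on an aromatic carbon. In words, this is bromo in place of methoxy on an aromatic carbon.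

Among the compounds with values here, no measured step touches that place. All three steps change the aryl group on the carbonyl carbon, and the two beyond the scatter, a 3.8-fold lower number from compound 1 to compound 3 (0.58 log units; beyond the scatter) and a 2.3-fold lower number from compound 2 to compound 3 (0.37 log units; beyond the scatter), are only modest. They therefore give no direction for this change, and no step beyond the scatter is expected in this assay. The expected step is a 1.4-fold lower number from compound 1 to compound 4 (0.15 log units; within the scatter). For compound 4 the estimated value is 17000 nM, with an expected range from 6500 nM to 45000 nM.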

Compound 4, concentration for 50% growth inhibition: 36200 nM
Estimate against measurement, compound 4: 2.1-fold (0.33 log units) below; the range from low to high includes it.
By their numbers in this assay, from the lowest: compound 3; then compounds 2, 1 and 4 (each within the scatter of the next, the first and the last beyond it).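

Among the compounds shown, this is the first reading at this place on the core, and in this assay bromo in place of methoxy gives a 1.5-fold higher number from compound 1 to compound 4 (0.18 log units; within the scatter), so this exchange on the aromatic carbon leaves no step that can be told from the scatter. The aryl group on the carbonyl carbon therefore remains the only place in this set where a step beyond the scatter is seen, as in a 3.8-fold lower number from compound 1 to compound 3 (0.58 log units; beyond the scatter). No measurement at hand bears on the reason for this result.

From the compounds shown here alone, what an amine or a hydroxy group at this place on the core would do stays open. Also open, going by these compounds, is whether bromo there would pair with the 3,4-dimethoxyphenyl on the carbonyl carbon as methoxy does in compound 3.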